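A few compounds are considered here, and "the series" means these few. Any claim that something is new, unique, unknown or untested is made for them only; others in the source may bear on it.

Measured in a functional assay on MDA-MB-231 cells (Homo sapiens) for inhibition, read by MTT assay; a higher number here means a weaker inhibitor of growth, a lower number a stronger inhibitor of growth:
- compound 1 `CC1=C(/C=C/C(C)=C/C=C/C(C)=C\C(=O)Nc2ccc(O)cc2)C(C)(C)CCC1n1ccnc1`: 13100 nM
- compound 2 `CC1=C(/C=C/C(C)=C/C=C/C(C)=C\C(=O)NCc2cccc(F)c2)C(C)(C)CCC1n1ccnc1`: 1650 nM
- compound 3 `CC1=C(/C=C/C(C)=C/C=C/C(C)=C\C(=O)NCc2ccc(O)cc2)C(C)(C)CCC1n1ccnc1`: 2230 nM

Compound 2, at 1650 nM, sits at the low end of these numbers, although a 1.4-fold higher number from compound 2 to compound 3 (0.13 log units; within the scatter) lies within the scatter. The next compound is compound 4 `CC1=C(/C=C/C(C)=C/C=C/C(C)=C\C(=O)Nc2ccccc2O)C(C)(C)CCC1n1ccnc1`, and the change is 2-hydroxyphenyl in place of 3-fluorobenzyl on an amide-type nitrogen.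

Within the data shown here, two measured steps bear on this change, and both go from a hydroxyphenyl to a benzyl-type group at that nitrogen: a 7.9-fold lower number from compound 1 to compound 2 (0.90 log units; beyond the scatter) and a 5.9-fold lower number from compound 1 to compound 3 (0.77 log units; beyond the scatter). Compound 4 returns to a hydroxyphenyl, as in compound 1, so a step of similar size in the opposite direction is expected in this assay, to a higher number and beyond the scatter. Among the measured compounds shown here, no measured compound yet carries 2-hydroxyphenyl, so the range stays wide. The expected change is a 6.1-fold higher number from compound 2 to compound 4 (0.78 log units; beyond the scatter). The estimate for compound 4 is 10000 nM, with an expected range of 3500 nM to 28000 nM.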

Compound 4, concentration for 50% growth inhibition: 4670 nM
The estimate for compound 4 lay 2.1-fold (0.33 log units) above the measured number; the measured number falls inside the stated range.
By their numbers in this assay, from the lowest: compounds 2 and 3 (each within the scatter of the next); then compound 4; then compound 1.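

In this assay, 2-hydroxyphenyl in place of 4-hydroxyphenyl on the amide-type nitrogen gives a 2.8-fold lower number from compound 1 to compound 4 (0.45 log units; beyond the scatter), so the two directly attached hydroxyphenyl groups are not equivalent and the place of the hydroxyl on the ring counts at this position. Compound 4 still reads higher than both benzyl-type compounds, with a 2.8-fold higher number from compound 2 to compound 4 (0.45 log units; beyond the scatter) and a 2.1-fold higher number from compound 3 to compound 4 (0.32 log units; beyond the scatter), so the gap to those groups narrows but does not close with 2-hydroxyphenyl. No supporting evidence bears on these steps.

Compound 3 and compound 4 differ both in the place of the hydroxyl and in the benzyl carbon, which leaves the separate contribution of each open. As far as these compounds go, how 2-hydroxybenzyl, 3-hydroxyphenyl or a longer 2-phenylethyl chain on this nitrogen would read in this assay also remains open.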